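The source may report more compounds than this note shows. Statements on the series, on what has been measured and on what is new or still open speak of the compounds shown alone.

Measured compounds:
compound 1 `Cc1cc(Cl)ccc1C(=O)N(C)c1cccnc1` — > 3000 nM
compound 2 `CCS(=O)(=O)N1CC(Oc2cncc(N3C(=O)c4ccc(Cl)cc4C3(C)C)c2)C1` — 4 nM

In an assay on cells for inhibition of cytochrome P450 11B2, mitochondrial (Homo sapiens), read by HTRF (a higher number here means a weaker inhibitor, a lower number a stronger inhibitor), compound 1 gives > 3000 nM, which is a limit of the assay and not a number. In this assay compound 2 gives 4 nM. Among the compounds with values here, no single-point step connects compound 1 and compound 2, so their two values show only that compound 2 is resolved where compound 1 is not. Compound 1 stands at the limit of > 3000 nM in this assay, at which 1 of the 2 values shown sits.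

Compound 3 `Cc1cc(Cl)ccc1C(=O)Nc1cccnc1` differs from compound 1 by hydrogen in place of methyl on an amide-type nitrogen. Within the data shown here, no measured pair isolates this change, so its direction in this assay is open, and no step beyond the usual scatter is assumed. Compound 3 is expected to give 3000 nM, in the range 700 nM to 15000 nM. The step of a number no higher from compound 1 to compound 3 (the limit leaves the size open) is estimated as essentially none, and a further limit-only read-out is considered likely.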

Compound 3, half-maximal inhibitory concentration: 277 nM
Compound 3: middle estimate off by 11-fold (1.03 log units), on the high side; the whole stated range lies above it.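

Hydrogen in place of methyl on the amide-type nitrogen gives, in this assay, an at least 10-fold lower number from compound 1 to compound 3 (1.03 log units; beyond the scatter). Within the data shown here, this is the first single-place step, and it shows that the substituent on this nitrogen matters for this series: the form carrying the amide hydrogen, compound 3, is resolved in this assay, whereas the methyl form is not. The true size of the step stays open on one side, because compound 1 stands at a limit: the limit of > 3000 nM in this assay, at which 1 of the 3 values shown sits.

Only methyl and hydrogen are shown on this nitrogen, so how an ethyl group or a longer chain would read there remains open. Compound 2 differs from compound 3 in more than one place, so no single change can be tied to the gap between their values.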